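Proline Amide in Place of Methylamide on a CDK8 Scaffold

This account rests on a few compounds, and the source may have more. Where it says the series, first, only, none or still open, it means among the compounds named here.

Measured compounds:
compound 1, `CNC(=O)/C=C/c1ccncc1-c1ccc2ccccc2c1`, in an assay on a protein complex for inhibition of CDK8/Cyclin C (Homo sapiens), with a stated time of 1 h, tested at 10 uM (on this read-out lower numbers stand for less inhibition and higher numbers for more inhibition at the one concentration tested (going by the name of the read-out)), gives 101%.
compound 2, `CNC(=O)COc1ccncc1-c1ccc2ccccc2c1`, in this assay gives 4%.

For the measured compounds named here, compound 1 stands highest of the two numbers; its nearest neighbour is compound 2, and the only measured step, a number 97 percentage points lower from compound 1 to compound 2 (beyond the scatter), lies beyond the scatter. That step, however, alters the linker between the core and the amide, not the amide nitrogen itself.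

Compound 3, `O=C(O)[C@@H]1CCCN1C(=O)/C=C/c1ccncc1-c1ccc2ccccc2c1`, has not yet been measured. It differs from compound 1 by 2-carboxypyrrolidin-1-yl in place of methylamino on a carbonyl carbon. Going by the values given here, no measured step touches this position, so the linker step gives only the background that the shape of the side chain matters on this scaffold; it does not say how the nitrogen substituent does.

Since compound 1 already sits at the top of the read-out in this assay, the writer expects at most a modest fall for compound 3, a number 16 percentage points lower from compound 1 to compound 3 (beyond the scatter), and estimates compound 3 at 85%, within 50% to 100%.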

Compound 3, a percentage reported as inhibition, at one concentration (the size of the read-out at that concentration, not a potency): 67%
For compound 3 the middle estimate is 18 percentage points above the measured one; the measured number falls inside the stated range.
By their numbers in this assay, from the lowest: compound 2; then compound 3; then compound 1.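

The change of methylamino to 2-carboxypyrrolidin-1-yl on the carbonyl carbon is the first one shown at this position, and in this assay it gives a number 34 percentage points lower from compound 1 to compound 3 (beyond the scatter), so what is attached to this carbonyl carbon does matter on the shared core, quite apart from the linker. The change is not all or nothing: with a much larger group in place, carrying a five-membered non-aromatic ring and a defined stereocentre, compound 3 still gives 67% at the one concentration tested, which is a size of read-out and not a potency. Nothing in the data shown accounts for the step.

Because this single step swaps everything at once, the compounds shown leave open whether the carboxylic acid, the five-membered ring or the defined stereocentre sets the size of the step. A plain pyrrolidin-1-yl group without the carboxylic acid, a dimethylamino group, or the methyl ester of the carboxylic acid on the same carbonyl carbon would each bear on that question.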